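Adding a hydroxy group to compound 1

This account rests on a few compounds, and the source may have more. Where it says the series, first, only, none or still open, it means among the compounds named here.

Compound 1 `c1ccc(-c2ccc(-c3ccc(-c4nc5ccccc5[nH]4)cc3)cc2)cc1`: 100000 nM
Compound 2 `FC(F)(F)Oc1ccc(-c2ccc(-c3ccc(-c4nc5ccccc5[nH]4)cc3)cc2)cc1`: 38400 nM

Within the data shown here, in a functional assay on SiHa cells (Homo sapiens) for inhibition, read by sulforhodamine B assay (on this read-out higher numbers stand for weaker inhibition of growth and lower numbers for stronger inhibition of growth), compound 1 gives 100000 nM, the higher of the two numbers measured so far, so it is the starting point with the weaker inhibition of growth. The next compound to be tested is compound 3 `Oc1cccc2[nH]c(-c3ccc(-c4ccc(-c5ccccc5)cc4)cc3)nc12`. It keeps the core of compound 1 and carries one change: hydroxy in place of hydrogen on an aromatic carbon. This is hydroxy in place of hydrogen on an aromatic carbon, on a six-membered aromatic ring of carbon only that is part of a fused or bridged system of two rings.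

Among the measured compounds shown here, only one measured step can serve as a guide: a 2.6-fold lower number from compound 1 to compound 2 (0.42 log units; beyond the scatter). That modest step came with trifluoromethoxy in place of hydrogen on an aromatic carbon. For the measured compounds named here, it involves a different group at a different place, and no hydroxy compound has been measured yet, so it is a loose guide. A similarly modest move towards a lower number is expected, and no change at all remains possible: a 2.2-fold lower number from compound 1 to compound 3 (0.35 log units; beyond the scatter). For compound 3 the estimated value is 45000 nM, with an expected range from 10000 nM to 100000 nM.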

Compound 3, concentration for 50% growth inhibition: 9710 nM
Estimate against measurement, compound 3: 4.6-fold (0.67 log units) above; measured number outside the range, below it.
By their numbers in this assay, from the lowest: compound 3; then compound 2; then compound 1.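

In this assay, hydroxy in place of hydrogen on an aromatic carbon of the six-membered aromatic ring of carbon only, part of a fused or bridged system of two rings, gives a 10-fold lower number from compound 1 to compound 3 (1.01 log units; beyond the scatter), a large step towards stronger inhibition of growth. So a change of just 1 heavy atom at this position is enough to shift the read-out well beyond the usual scatter, which the only earlier step, the modest 2.6-fold lower number from compound 1 to compound 2 (0.42 log units; beyond the scatter) made with trifluoromethoxy at a different place, did not show. No measurement here explains how the hydroxy group produces this gain.

The compounds shown leave open whether the gain belongs to the hydroxy group itself or whether another group on the same carbon, such as a methoxy group or an amine, would give a step of similar size. They also leave open whether hydroxy would have the same effect on another carbon of that ring, or whether this one position is special.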